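A few compounds are considered here, and "the series" means these few. Any claim that something is new, unique, unknown or untested is made for them only; others in the source may bear on it.

In a functional assay on the whole organism for antagonist activity, with Mus musculus as the target (a lower number here means that less compound is needed, a higher number that more compound is needed for the effect), measured so far:
- Compound 1 `Cn1c(-c2cccc3ccccc23)nnc1S(C)(=O)=O`: > 200 mg/kg
- Compound 2 `COc1ccc(-c2nnc(S(C)(=O)=O)n2C)cc1`: > 200 mg/kg
- Compound 3 `CSc1nnc(-c2ccccc2Cl)n1C`: > 50 mg/kg

All three entries are limits of the assay, not numbers. Compound 3 therefore has no exact position in the series, and its limit is > 50 mg/kg. Compound 4 `CSc1nnc(-c2ccccc2F)n1C` has fluoro in place of chloro on an aromatic carbon. Among the compounds with values here, no measured step in this assay gives a guide to the size of this change, so no shift beyond the usual scatter is expected, in either direction. The expected step of a number no higher from compound 3 to compound 4 (the limit leaves the size open) is correspondingly an estimate with wide uncertainty. For compound 4, the estimated value is 50 mg/kg, with an expected range of 15 mg/kg to 200 mg/kg.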

Compound 4, dose for half-maximal effect: 61.3 mg/kg
Compound 4: the middle estimate sits 1.2-fold (0.09 log units) below what was measured, within the range that was stated.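

Compound 3 is recorded only as a limit, > 50 mg/kg. Within the data shown here, compound 4 reads 61.3 mg/kg, so no step from compound 3 to compound 4 can be read. From the compounds shown here alone, whether fluoro in place of chloro on an aromatic carbon shifts the dose remains open.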